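The compounds below may be only part of what the source reports. "The series", "measured", "known", "first", "only" and "open" are said of these compounds alone.

Compound 1 `Brc1cccc2c1nnn2CC1CC1` is the starting point here. Going by the values given here, in an ADME assay on microsomes from liver (Rattus norvegicus, strain Wistar) for metabolic stability, tested at 2.5 uM (a lower number here means slower removal, a higher number faster removal of the compound), compound 1 gives 0.6 mL/min/g, the highest of the two numbers measured so far. Among the compounds with values here, its only measured neighbour, compound 2 `Fc1cc(Br)c2nnn(CC3CC3)c2c1`, gives 0.5 mL/min/g in this assay, and the single measured step, a 1.2-fold lower number from compound 1 to compound 2 (0.08 log units; within the scatter), comes from fluoro in place of hydrogen on an aromatic carbon; it is too small to count as a real change.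

Compound 3 `Clc1cccc2c1nnn2CC1CC1` has not yet been measured in this assay. It differs from compound 1 in one place: chloro in place of bromo on an aromatic carbon. Within the data shown here, no measured step in this set concerns the exchange of one halogen for another, so the only guide is the step from compound 1 to compound 2, which stayed within the scatter and suggests that small changes on the shared core leave this assay roughly unchanged. On that basis the expected step is a 1.2-fold lower number from compound 1 to compound 3 (0.08 log units; within the scatter), meaning nothing beyond the scatter in either direction. For compound 3 the estimated value is 0.5 mL/min/g, with a range from 0.25 mL/min/g to 1 mL/min/g.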

Compound 3, intrinsic clearance in a liver preparation (reported as CLH), per the amount of preparation that the assay uses: 0.5 mL/min/g
Beside the measured number, compound 3's estimate shows no gap at the digits printed, and the stated range covers the measured number.
By their numbers in this assay, from the lowest: compounds 2, 3 and 1 (each within the scatter of the next).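

In this assay the exchange of bromo for chloro gives a 1.2-fold lower number from compound 1 to compound 3 (0.08 log units; within the scatter), so the two halogens cannot be told apart at this place, on an aromatic carbon of the six-membered ring of carbon only. Going by these compounds alone, compound 2 kept its bromo and differed from compound 1 elsewhere on the shared core, so this is the first measured step at the halogen's own position, and it shows that at least this one exchange of one halogen for another leaves the read-out within the usual scatter. Nothing given here explains this result or connects it to any property of the two groups.

Bromo and chloro are close relatives, each a single halogen atom with no hydrogen-bond donors or acceptors, so this step says little about how much freedom the position allows, and a compound with plain hydrogen, an amine, a nitrile or a carboxylic acid there would test that far more sharply. On these data alone, whether the halogen matters at all to this assay therefore stays open, as does whether the same exchange would behave alike on a core carrying a longer chain.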